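Ring swap on the shared core: lactam to cyclic sulfonamide

This account rests on a few compounds, and the source may have more. Where it says the series, first, only, none or still open, it means among the compounds named here.

Compound 1 `CC(C)c1noc(N2CCC(Oc3cc(N4CCc5cc(N6CCCCC6=O)ccc54)ncn3)CC2)n1` is the highest of the three compounds measured in a physicochemical assay for lipophilicity, measured as octanol-water partition, at pH 7.4 (on this read-out lower numbers stand for lower lipophilicity and higher numbers for higher lipophilicity), where compound 1 gives 3.8. Compound 2 `CC(C)c1noc(N2CCC(Oc3cc(N4CCc5cc(N6CCOCC6=O)ccc54)ncn3)CC2)n1` gives 3.1 in this assay, and compound 3 `CC(C)c1noc(N2CCC(Oc3cc(N4CCc5cc(N6CCC(O)CC6=O)ccc54)ncn3)CC2)n1` gives 2.8. Both steps away from compound 1 go down: a number 0.70 log units lower from compound 1 to compound 2 (beyond the scatter), and a number 1.00 log units lower from compound 1 to compound 3 (beyond the scatter). The step of a number 0.30 log units lower from compound 2 to compound 3 (within the scatter) does not leave the scatter.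

Compound 4 `CC(C)c1noc(N2CCC(Oc3cc(N4CCc5cc(N6CCCS6(=O)=O)ccc54)ncn3)CC2)n1` is not yet measured. It differs from compound 1 in one place: a group of 7 heavy atoms (3 carbon, 1 nitrogen, 2 oxygen, 1 sulfur; one five-membered non-aromatic ring with 2 hetero atoms) in place of a group of 7 heavy atoms (5 carbon, 1 nitrogen, 1 oxygen; one six-membered non-aromatic ring with 1 hetero atom), on an aromatic carbon. The group that enters carries two hydrogen-bond acceptors and one sulfur where the group that leaves carries one acceptor and no sulfur, and it sits on the same aromatic carbon of the six-membered ring of carbon only, part of the fused system of two rings.

The two steps that bear on this change are those from compound 1, both exchanges at the same position that added polar atoms to the six-membered non-aromatic ring and lowered the number by a modest amount. A step of similar size and direction is therefore expected here: a number 0.70 log units lower from compound 1 to compound 4 (beyond the scatter). Compound 4 is estimated at 3.1 in this assay, within a range from 2.6 to 3.6.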

Compound 4, distribution coefficient: 3.2
For compound 4 the middle estimate is 0.10 log units below the measured one; measured number inside the range.
By their numbers in this assay, from the lowest: compounds 3, 2 and 4 (each within the scatter of the next, the first and the last beyond it); then compound 1.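

In this assay, the position on the aromatic carbon also accepts a five-membered ring carrying sulfur, not only six-membered rings, and the number still falls, with a number 0.60 log units lower from compound 1 to compound 4 (beyond the scatter) in the same direction as the two earlier steps away from 2-oxopiperidin-1-yl. This new ring size and added sulfur do not separate the group from the 3-oxomorpholin-4-yl group, as a number 0.10 log units higher from compound 2 to compound 4 (within the scatter) shows, so two groups of different ring size and atom make-up read alike at this position. Among these compounds, the hydroxy-bearing group stays apart from the new one, with a number 0.40 log units higher from compound 3 to compound 4 (beyond the scatter), which gives the first step at this position that is beyond the scatter and leaves 4-hydroxy-2-oxopiperidin-1-yl lowest of the set against compound 4.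

Ring size and the swap from carbonyl to cyclic sulfonamide change together in compound 4, so their shares of the step cannot be divided, and a six-membered cyclic sulfonamide, an open-chain methanesulfonamide or a basic piperazine at the same place would be needed to pull them apart. Nothing shown gives a measured reason for any of these steps.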